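Chloro on the triazole aryl: single-ring change

The compounds below may be only part of what the source reports. "The series", "measured", "known", "first", "only" and "open" are said of these compounds alone.

Compound 3 `O=c1[nH]cc(S(=O)(=O)Nc2ccc(-c3cn(-c4ccccc4)nn3)cc2)c(=O)[nH]1` gives 18800 nM in a functional assay on SGC-7901 cells (Homo sapiens) for antiproliferative activity, read by MTT assay, with a stated time of 24 h (a higher number here means a weaker inhibitor, a lower number a stronger inhibitor), the highest of the three numbers measured. Compound 1 `Cc1ccc(-n2cc(-c3ccccc3NS(=O)(=O)c3c[nH]c(=O)[nH]c3=O)nn2)cc1` gives 6390 nM and compound 2 `O=c1[nH]cc(S(=O)(=O)Nc2ccccc2-c2cn(-c3cccc(Cl)c3)nn2)c(=O)[nH]1` gives 2270 nM; both steps down from compound 3 are beyond the scatter, so compound 3 is the weakest inhibitor of the three. Going by the values given here, the one step between single-change pairs is a 2.8-fold lower number from compound 1 to compound 2 (0.45 log units; beyond the scatter), a modest lowering when 3-chlorophenyl replaces 4-methylphenyl on the aromatic nitrogen. Compound 4 `O=c1[nH]cc(S(=O)(=O)Nc2ccc(-c3cn(-c4ccccc4Cl)nn3)cc2)c(=O)[nH]1` carries chloro in place of hydrogen on an aromatic carbon, that is, phenyl to 2-chlorophenyl, ortho to a large group. Among the compounds with values here, the step from compound 1 to compound 2 is the only measured change that bears on it, but it joins a change of position to a change of group, so its size transfers loosely at best. A chlorine entering the ring on the aromatic nitrogen is expected to lower the number, if at all, by less than that step. Compound 4 is expected at 12000 nM, with a range from 5000 nM to 28000 nM. The step of a 1.6-fold lower number from compound 3 to compound 4 (0.19 log units; within the scatter) is thus expected to sit near the edge of the scatter.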

Compound 4, half-maximal inhibitory concentration: 2680 nM
The estimate for compound 4 lay 4.5-fold (0.65 log units) above the measured number; measured number below the stated range.
By their numbers in this assay, from the lowest: compounds 2 and 4 (each within the scatter of the next); then compound 1; then compound 3.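

In this assay, the step of a 7.0-fold lower number from compound 3 to compound 4 (0.85 log units; beyond the scatter) shows that chloro in place of hydrogen on this aromatic carbon, ortho to a large group, is enough on its own to move the number beyond the scatter. The earlier step of a 2.8-fold lower number from compound 1 to compound 2 (0.45 log units; beyond the scatter) joined a change of position to a change of group, whereas this pair isolates one added chlorine on an otherwise unchanged compound, so the phenyl to 2-chlorophenyl change can be read directly. No measurement shown here accounts for the size of this step.

The compounds shown leave open whether the step belongs to chlorine itself or to any group at this place on the ring. A 2-fluorophenyl, 2-methylphenyl or 2-methoxyphenyl analogue of compound 3 would separate these readings.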